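Sulfamoyl for Methylsulfonyl, Repeated on a Second Core

The compounds below may be only part of what the source reports. "The series", "measured", "known", "first", "only" and "open" are said of these compounds alone.

Compound 1 `CC(=O)Oc1ccc(/C=C/C(=O)OCCSc2nc(-c3ccc(S(C)(=O)=O)cc3)n(-c3ccc(F)cc3)n2)cc1OC(C)=O` was tested in a functional assay on A549 cells (Homo sapiens) for antiproliferative activity, read by MTT assay, with a stated time of 72 h (a lower number here means a stronger inhibitor, a higher number a weaker inhibitor), where compound 1 gives 11800 nM. Compound 2 `CC(=O)Oc1ccc(/C=C/C(=O)OCCSc2nc(-c3ccc(S(N)(=O)=O)cc3)n(-c3ccc(F)cc3)n2)cc1OC(C)=O` carries the change (amino in place of methyl on a sulfonyl sulfur), and in this assay compound 2 gives 12000 nM. That exchange produced a 1.0-fold higher number from compound 1 to compound 2 (0.01 log units; within the scatter).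

Compound 3 `CS(=O)(=O)c1ccc(-c2nc(SCCOC(=O)/C=C/c3ccc(O)c(O)c3)nn2-c2ccccc2)cc1` stands on a different core; how the core of compound 3 differs from the core of compound 1 is not broken down here. In this assay compound 3 gives 13800 nM, a number that lies within the scatter of both compound 1 and compound 2.

Compound 4 `NS(=O)(=O)c1ccc(-c2nc(SCCOC(=O)/C=C/c3ccc(O)c(O)c3)nn2-c2ccccc2)cc1` has not yet been measured. It differs from compound 3 by amino in place of methyl on a sulfonyl sulfur, the same change that separated compound 1 from compound 2, at a place described in identical words. The expected step is a 1.0-fold higher number from compound 3 to compound 4 (0.01 log units; within the scatter), resting on the observation that the same change gave a 1.0-fold higher number from compound 1 to compound 2 (0.01 log units; within the scatter). For compound 4 the estimate in this assay is 14000 nM, with a likely range from 7000 nM to 28000 nM.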

Compound 4, half-maximal inhibitory concentration: 14100 nM
The estimate for compound 4 lay 1.0-fold (0.00 log units) below the measured number; measured number inside the range.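

In this assay, amino in place of methyl on a sulfonyl sulfur gave a 1.0-fold higher number from compound 3 to compound 4 (0.01 log units; within the scatter). Set beside the earlier step, the exchange of methylsulfonyl for sulfamoyl behaved alike on the two cores, with no step of measurable size on either: the same change on two cores in this assay, a 1.0-fold higher number (0.01 log units; within the scatter) from compound 1 to compound 2 and a 1.0-fold higher number (0.01 log units; within the scatter) from compound 3 to compound 4, 1.0-fold (0.00 log units) apart, within the scatter of two such steps. Within the data shown here, this shows only that the exchange left the number within the scatter on both of these cores; with no step of real size on either, it does not show that a larger effect would carry from one core to another, and it says nothing about any further core.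

The compounds shown leave open how a dimethylamino group on the sulfonyl sulfur, or a carboxylic acid in place of the whole methylsulfonyl group, would read in this assay. They also leave open whether a longer chain in the link to the ester would change the picture, and whether the exchange would stay this quiet in any other test.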